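A few compounds are considered here, and "the series" means these few. Any claim that something is new, unique, unknown or untested is made for them only; others in the source may bear on it.

Measured compounds in a functional assay on HEK293T cells for agonist activity at histamine H2 receptor (Homo sapiens), read by beta-arrestin recruitment; a lower number here means that less compound is needed, a higher number that more compound is needed for the effect:
compound 1, `Cc1nc(N)sc1CCCN/C(N)=N/C(=O)NCC(C)CCc1ccccc1`, gives 355 nM
compound 2, `Cc1nc(N)sc1CCCN/C(N)=N/C(=O)NC(c1ccccc1)c1ccccc1`, gives 331 nM

Compound 1 has the higher of the two numbers in this assay, but its nearest neighbour, compound 2, lies within the usual scatter of it, so no order between the two can be read. Going by the values given here, no single-point step between measured compounds is available in the set.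

Compound 3, `Cc1nc(N)sc1CCCN/C(N)=N/C(=O)NCC(C)CCCc1ccccc1`, has not been measured in this assay. It differs from compound 1 in one place: benzyl in place of phenyl on a saturated chain carbon, four bonds along the chain from an amide-type nitrogen. The same difference, cut one bond further out, reads benzyl to phenethyl, or phenethyl to 3-phenylpropyl; it amounts to a lengthening of the saturated chain by one carbon. Among the compounds with values here, nothing among the measured compounds tells how this assay answers such a lengthening, since compound 2 differs from compound 1 in more than one place. The step from compound 1 to compound 3 is therefore expected to be small, with no direction beyond the scatter, that is a 1.0-fold lower number from compound 1 to compound 3 (0.01 log units; within the scatter). Compound 3 is expected to give about 350 nM in this assay, with a range from 140 nM to 900 nM.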

Compound 3, half-maximal effective concentration: 2510 nM
For compound 3 the middle estimate is 7.2-fold (0.86 log units) below the measured one; the measured number lies above the stated range.
By their numbers in this assay, from the lowest: compounds 2 and 1 (each within the scatter of the next); then compound 3.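

In this assay, this position on the saturated chain does respond to chain length: benzyl in place of phenyl, four bonds along the chain from an amide-type nitrogen, gives a 7.1-fold higher number from compound 1 to compound 3 (0.85 log units; beyond the scatter). Going by these compounds alone, the earlier compounds offered no single-place step, so this is the first reading of how the assay answers any change in this side chain, and here the lengthening of the saturated chain goes with more compound being needed for the effect. The change adds only chain length, with the aromatic ring and the counts of hydrogen-bond donors, acceptors and net charge the same on both sides, but no measurement bears on why the number moves, so the step stands without an explanation.

A single step cannot show whether the trend continues with a longer chain, such as one ending in 4-phenylbutyl, or reverses with a shorter one. It also leaves open how this position answers a group of another kind at the chain end, such as an amine or a carboxylic acid in place of the phenyl ring.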